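A Second Trifluoromethyl Group on Compound 1

A few compounds are considered here, and "the series" means these few. Any claim that something is new, unique, unknown or untested is made for them only; others in the source may bear on it.

In a functional assay on CWR22R cells (Homo sapiens) for antiproliferative activity, read by propidium iodide staining, with a stated time of 96 h (a lower number here means a stronger inhibitor, a higher number a weaker inhibitor), compound 1 (`CC(O)(COc1cccc(C(F)(F)F)c1)C(=O)Nc1ccc(S(F)(F)(F)(F)F)cc1`) gives 14600 nM, compound 2 (`CC(O)(COc1cccc(OC(F)(F)F)c1)C(=O)Nc1ccc(S(F)(F)(F)(F)F)cc1`) gives 17300 nM and compound 3 (`CC(O)(COc1ccc(C#N)c(F)c1)C(=O)Nc1ccc(S(F)(F)(F)(F)F)cc1`) gives 24300 nM in the same test. Compound 1 stands level with both: the step is a 1.2-fold higher number from compound 1 to compound 2 (0.07 log units; within the scatter) in one case and a 1.7-fold higher number from compound 1 to compound 3 (0.22 log units; within the scatter) in the other.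

Compound 4 (`CC(O)(COc1cc(C(F)(F)F)cc(C(F)(F)F)c1)C(=O)Nc1ccc(S(F)(F)(F)(F)F)cc1`) differs from compound 1 in one place, with trifluoromethyl in place of hydrogen on an aromatic carbon. The measured steps bear on this change only loosely: each swaps one group for another, and neither adds a group where a hydrogen stood. For the measured compounds named here, with a 1.2-fold higher number from compound 1 to compound 2 (0.07 log units; within the scatter) and a 1.7-fold higher number from compound 1 to compound 3 (0.22 log units; within the scatter) as the only guide, no step beyond the scatter is expected in this assay for compound 4. The estimated step is a 1.0-fold lower number from compound 1 to compound 4 (0.02 log units; within the scatter) on this reasoning. For compound 4 the expected value is 14000 nM with an estimated range from 6000 nM to 30000 nM in this test.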

Compound 4, half-maximal inhibitory concentration: 7000 nM
Compound 4: middle estimate off by 2.0-fold (0.30 log units), on the high side, and the stated range covers the measured number.
By their numbers in this assay, from the lowest: compound 4; then compounds 1, 2 and 3 (each within the scatter of the next).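

In this assay, trifluoromethyl in place of hydrogen on an aromatic carbon gives a 2.1-fold lower number from compound 1 to compound 4 (0.32 log units; beyond the scatter), a modest change but the only step shown that lies beyond the scatter. The earlier swaps replaced one group with another and left the number level, whereas this one shows that adding a group of 4 heavy atoms where a hydrogen stood, meta to a trifluoromethyl group, lowers the number rather than raising it. No measurement available here gives a reason for this step.

The compounds shown leave open whether the drop is particular to trifluoromethyl or would also appear with a chlorine atom, a methyl group or an amine on the same carbon. They also leave open whether trifluoromethyl in place of hydrogen would give a similar step on compound 2 or compound 3.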